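Extending the fluorinated chain on the shared core

This account rests on a few compounds, and the source may have more. Where it says the series, first, only, none or still open, it means among the compounds named here.

The series keeps one core bearing a trifluoromethyl group and a phenyl group, with a triazolylmethyl arm whose chain varies. Compound 1 `O=c1c2c(C(F)(F)F)cc(-c3ccccc3)nc2ncn1Cc1cn(CCC(F)(F)C(F)(F)C(F)(F)C(F)(F)C(F)(F)C(F)(F)C(F)(F)C(F)(F)F)nn1` carries a long perfluorinated chain, compound 2 `CCCCCCCCCCn1cc(Cn2cnc3nc(-c4ccccc4)cc(C(F)(F)F)c3c2=O)nn1` a decyl chain, and compound 3 `Cc1nc2nc(-c3ccccc3)cc(C(F)(F)F)c2c(=O)n1Cc1cn(CCC(F)(F)C(F)(F)C(F)(F)C(F)(F)C(F)(F)C(F)(F)F)nn1` a methyl on the core together with a shorter perfluorinated chain. In a functional assay on U-937 cells (Homo sapiens) for cytotoxicity, read by MTT assay, with a stated time of 24 h (on this read-out lower numbers stand for stronger inhibition and higher numbers for weaker inhibition), compound 1 gives only a limit, > 200 ug/mL. Compound 2 gives 8.16 ug/mL in this assay. Compound 3 gives only a limit in this assay, > 200 ug/mL. Compound 3 therefore stands at the limit of > 200 ug/mL in this assay, at which 2 of the 3 values shown sit. Compound 4 `Cc1nc2nc(-c3ccccc3)cc(C(F)(F)F)c2c(=O)n1Cc1cn(CCC(F)(F)C(F)(F)C(F)(F)C(F)(F)C(F)(F)C(F)(F)C(F)(F)C(F)(F)F)nn1` differs from compound 3 by 1,1,2,2,2-pentafluoroethyl in place of fluoro on a saturated chain carbon bound to two fluorine atoms and a saturated chain carbon. Going by the values given here, no step between measured compounds is available here. The expected step that the limit leaves unreadable from compound 3 to compound 4 is none beyond the scatter, with compound 4 likely remaining at the limit. Compound 4 is estimated at 300 ug/mL, within 150 ug/mL to 1000 ug/mL.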

Compound 4, half-maximal inhibitory concentration: 124 ug/mL
Compound 4: middle estimate off by 2.4-fold (0.38 log units), on the high side; the whole stated range lies above it.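

Replacing fluoro with 1,1,2,2,2-pentafluoroethyl on a saturated chain carbon bound to two fluorine atoms and a saturated chain carbon gives an at least 1.6-fold lower number from compound 3 to compound 4 (0.20 log units; that floor lies within the scatter) in this assay. Methyl in place of hydrogen on an aromatic carbon gives an at least 1.6-fold lower number from compound 1 to compound 4 (0.20 log units; that floor lies within the scatter), so compound 4 is the first perfluorinated compound here with a number rather than a limit. Neither floor goes beyond the scatter, and the true size of each step stays unread, as each starts from a limit: the limit of > 200 ug/mL in this assay, at which 2 of the 4 values shown sit.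

Still open, going by these compounds, is whether a longer perfluorinated chain, or an amine in place of the chain, would move the number. On these data alone, the effect of the same methyl alongside the decyl chain of compound 2 is also open.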